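Amino-chain variation on the shared core

This account rests on a few compounds, and the source may have more. Where it says the series, first, only, none or still open, it means among the compounds named here.

Measured compounds:
compound 1, `CCCNc1nc(SC)nc2ncccc12`, gives 270 nM in a functional assay (Nicotiana tabacum); a higher number here means a weaker inhibitor, a lower number a stronger inhibitor
compound 2, `CCCCCCCNc1nc(SC)nc2ncccc12`, gives 4070 nM in this assay
compound 3, `CSc1nc(NC2CCC2)c2cccnc2n1`, gives 720 nM in this assay

Compound 1 stands lowest of the three numbers in this assay, with compound 3 nearest and compound 2 furthest away. Both steps away from compound 1 raise the number beyond the scatter: a 2.7-fold higher number from compound 1 to compound 3 (0.43 log units; beyond the scatter) is modest, whereas a 15-fold higher number from compound 1 to compound 2 (1.18 log units; beyond the scatter) is large.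

Compound 4, `CCOCCNc1nc(SC)nc2ncccc12`, is not yet measured. It differs from compound 1 as follows: ethoxy in place of methyl on a saturated chain carbon, two bonds along the chain from a nitrogen on an aromatic ring. In effect the propyl chain on the ring nitrogen becomes a 2-ethoxyethyl chain, so the substituent grows longer, as it did from compound 1 to compound 2, though by fewer atoms and with an oxygen in the chain. The step of a 15-fold higher number from compound 1 to compound 2 (1.18 log units; beyond the scatter) bears on this most directly and points upward; the step of a 2.7-fold higher number from compound 1 to compound 3 (0.43 log units; beyond the scatter) shows that even a small change at this nitrogen moves the number beyond the scatter. Among the measured compounds shown here, no measured compound carries an ether in this chain, so the size of the step is uncertain.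

Compound 4 is therefore expected to give a higher number than compound 1, by a 3.3-fold higher number from compound 1 to compound 4 (0.52 log units; beyond the scatter), estimated at 900 nM with a range of 300 nM to 2700 nM.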

Compound 4, half-maximal inhibitory concentration: 7590 nM
The estimate for compound 4 lay 8.4-fold (0.93 log units) below the measured number; the whole stated range lies below it.
By their numbers in this assay, from the lowest: compound 1; then compound 3; then compounds 2 and 4 (each within the scatter of the next).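

In this assay the change from propyl to 2-ethoxyethyl on the nitrogen of the shared core is among the largest moves seen at this position: a 28-fold higher number from compound 1 to compound 4 (1.45 log units; beyond the scatter) is large, and an 11-fold higher number from compound 3 to compound 4 (1.02 log units; beyond the scatter) is large too, so neither the straight propyl chain nor the cyclobutyl ring tolerates replacement by this ether chain. Placing an oxygen in the chain does not keep the number near that of compound 1, and the two long chains cannot be told apart, as a 1.9-fold higher number from compound 2 to compound 4 (0.27 log units; within the scatter) stays inside the scatter even though the chain of compound 2 carries no oxygen. Nothing available on these compounds explains why the ether chain behaves like the longer all-carbon chain.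

Still open, as far as these compounds go, is whether the rise sets in gradually with chain length, which a butyl or pentyl chain on this nitrogen would test, and whether a shorter ether such as 2-methoxyethyl keeps the number closer to that of compound 1. Equally open, from the compounds shown here alone, is how a chain ending in a hydroxyl group, an amine or a carboxylic acid would behave at this position, since the only heteroatom tried in the chain so far is the ether oxygen of compound 4.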